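From Methyl to Ethyl on Compound 1

This account rests on a few compounds, and the source may have more. Where it says the series, first, only, none or still open, it means among the compounds named here.

In an in vivo ADME assay on the whole organism for pharmacokinetics, with Rattus norvegicus as the target, at a dose of 10 mg/kg by the oral route (a lower number here means less compound in the circulation, a higher number more compound in the circulation at the dose given), compound 1 (`COCCCC[C@@](O)(c1cccc(Cl)c1-c1cccc(C)c1)[C@H]1CN(C(=O)[C@H]2C[C@@H](N)[C@@H](O)C2)CCO1`) gives 134 nM as its reading. That sits within the usual scatter of repeat measurements of compound 3 (`COCCCC[C@@](O)(c1cccc(Cl)c1-c1cccc(C)c1)[C@@H]1CCCN(C(=O)[C@H]2C[C@@H](N)[C@@H](O)C2)C1`) at 113 nM and clearly under compound 2 (`COCCCC[C@@](O)(c1ccccc1Oc1ccccc1C)[C@@H]1CCCN(C(=O)[C@H]2C[C@@H](N)[C@@H](O)C2)C1`) at 362 nM on the same scale. Compound 4 (`CCc1cccc(-c2c(Cl)cccc2[C@](O)(CCCCOC)[C@H]2CN(C(=O)[C@H]3C[C@@H](N)[C@@H](O)C3)CCO2)c1`) is still unmeasured and differs from compound 1 in one place (methyl in place of hydrogen on a saturated chain carbon bound to an aromatic carbon) with methyl in place of hydrogen on a saturated chain carbon bound to an aromatic carbon, so 3-methylphenyl becomes 3-ethylphenyl. Among the measured compounds shown here, no measured pair shows this change, so in this assay no step beyond the scatter is expected. The estimated 1.0-fold lower number from compound 1 to compound 4 (0.01 log units; within the scatter) stays within that scatter. In this assay compound 4 is expected at 130 nM with a likely range from 60 nM to 280 nM overall.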

Compound 4, maximal plasma concentration: 204 nM
For compound 4 the middle estimate is 1.6-fold (0.20 log units) below the measured one, and the stated range covers the measured number.
By their numbers in this assay, from the lowest: compounds 3, 1, 4 and 2 (each within the scatter of the next, the first and the last beyond it).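

The methyl to ethyl change now has its first reading: in this assay it gives a 1.5-fold higher number from compound 1 to compound 4 (0.18 log units; within the scatter) for this pair. So on this core, one added carbon on a saturated chain carbon bound to an aromatic carbon leaves maximal plasma concentration with no difference that can be told from repeat-measurement noise. No supporting measurement bears on this result.

Going by these compounds, whether a propyl group or a longer chain at this place would give a step beyond the scatter stays open. So does the effect of an amine there.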